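This account rests on a few compounds, and the source may have more. Where it says the series, first, only, none or still open, it means among the compounds named here.

Three esters sharing one core have been measured in a functional assay on CaEs17 cells (Homo sapiens) for inhibition, read by MTT assay; on this read-out higher numbers stand for weaker inhibition and lower numbers for stronger inhibition. Compound 1, `C=C1C(=O)[C@@]23C(=O)OC[C@]4([C@@H](OC(C)=O)CCC(C)(C)[C@H]4C=O)[C@@H]2CC[C@H]1[C@H]3OC(=O)c1ccc(C(F)(F)F)cc1`, gives 9160 nM. Compound 2, `C=C1C(=O)[C@@]23C(=O)OC[C@]4([C@@H](OC(C)=O)CCC(C)(C)[C@H]4C=O)[C@@H]2CC[C@H]1[C@H]3OC(=O)CCCC`, gives 2850 nM, and compound 3, `C=C1C(=O)[C@@]23C(=O)OC[C@]4([C@@H](OC(C)=O)CCC(C)(C)[C@H]4C=O)[C@@H]2CC[C@H]1[C@H]3OC(=O)CC`, gives 2770 nM. Among these three compound 3 carries the lowest number, but its distance to compound 2, a 1.0-fold lower number from compound 2 to compound 3 (0.01 log units; within the scatter), is within the scatter, so the two cannot be ordered; the step of a 3.3-fold lower number from compound 1 to compound 3 (0.52 log units; beyond the scatter) is beyond the scatter, as is a 3.2-fold lower number from compound 1 to compound 2 (0.51 log units; beyond the scatter).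

Compound 4, `C=C1C(=O)[C@@]23C(=O)OC[C@]4([C@@H](OC(C)=O)CCC(C)(C)[C@H]4C=O)[C@@H]2CC[C@H]1[C@H]3OC(=O)c1ccc(Cl)cc1`, differs from compound 3 in one place: 4-chlorophenyl in place of ethyl on a carbonyl carbon. The measured step that bears on this change is a 3.3-fold lower number from compound 1 to compound 3 (0.52 log units; beyond the scatter), read in reverse: putting 4-(trifluoromethyl)phenyl in place of ethyl on a carbonyl carbon raised the number in this assay by a modest amount. Because of a 3.3-fold lower number from compound 1 to compound 3 (0.52 log units; beyond the scatter), and since 4-chlorophenyl is likewise a six-membered aromatic ring of carbon only entering on a carbonyl carbon, a rise of roughly that modest size is expected for compound 4, though compound 1 is the only aryl ester measured, so the size is uncertain. The expected step is a 2.3-fold higher number from compound 3 to compound 4 (0.37 log units; beyond the scatter). Compound 4 is therefore estimated at 6500 nM, with a range from 3000 nM to 14000 nM.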

Compound 4, half-maximal inhibitory concentration: 1250 nM
Compound 4: middle estimate off by 5.2-fold (0.72 log units), on the high side; measured number outside the range, below it.
By their numbers in this assay, from the lowest: compound 4; then compounds 3 and 2 (each within the scatter of the next); then compound 1.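

In this assay the aryl ester compound 4 moves the opposite way from compound 1, so a six-membered aromatic ring on this carbonyl carbon does not by itself raise the number: 4-chlorophenyl in place of ethyl gives a lower number (a 2.2-fold lower number from compound 3 to compound 4 (0.35 log units; beyond the scatter)), and 4-chlorophenyl in place of butyl does the same (a 2.3-fold lower number from compound 2 to compound 4 (0.36 log units; beyond the scatter)). The direction of the change from chain to ring is instead set by what the ring carries, since chloro in place of trifluoromethyl on an aromatic carbon spans the widest gap among these four esters (a 7.3-fold lower number from compound 1 to compound 4 (0.86 log units; beyond the scatter)), with compounds 2 and 3 lying between the two aryl esters. No measurement offered here explains why these two ring groups part in this way.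

The compounds shown leave open where a plain phenyl, a 4-fluorophenyl or a 4-methoxyphenyl ester would fall, as two substituted rings give only two points on this ring. They also leave open whether a chain longer than butyl, such as octyl, or a chain ending in an amine would stay level with compounds 2 and 3.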